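Amide-nitrogen substituents and lipophilicity in the series

This account rests on a few compounds, and the source may have more. Where it says the series, first, only, none or still open, it means among the compounds named here.

Measured so far:
compound 1 `CNC(=O)c1cc(C)n(Cc2cc(Cl)ccc2OCc2ccccc2)n1` — > 3.7
compound 2 `Cc1cc(C(=O)Nc2ccc(F)cc2)nn1Cc1cc(Cl)ccc1OCc1ccccc1` — 3

In a physicochemical assay for lipophilicity, at pH 7.4 (a higher number here means a more lipophilic compound, a lower number a more polar compound), compound 1 returns only a limit, > 3.7, not a number. For the measured compounds named here, compound 2 gives 3 in this assay, the only actual number. Going by the values given here, the step of a number at least 0.70 log units lower from compound 1 to compound 2 (beyond the scatter) is the single measured step, and it starts from the limit of > 3.7 in this assay, at which 1 of the 2 values shown sits, rather than from a number.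

Compound 3 `Cc1cc(C(=O)NCc2ccccn2)nn1Cc1cc(Cl)ccc1OCc1ccccc1` is not yet measured. It differs from compound 2 by (pyridin-2-yl)methyl in place of 4-fluorophenyl on an amide-type nitrogen. Among the compounds with values here, no measured step bears directly on this change: the one step known, a number at least 0.70 log units lower from compound 1 to compound 2 (beyond the scatter), concerns a different pair of groups at the same place, and its size is only a lower bound. The expectation therefore rests on what compound 2 shows in this assay together with the counted difference. For compound 3 in this assay the estimate is 2.1, with a range of 1.5 to 2.7. The step this estimate means, a number 0.90 log units lower from compound 2 to compound 3 (beyond the scatter), is expected to lie beyond the scatter, downward.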

Compound 3, distribution coefficient: > 3.7
Compound 3 ended at the assay's limit; the forecaster's own chance of this, stated with the estimate: 5%; at least 1.60 log units between middle value and limit.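

At the amide-type nitrogen, (pyridin-2-yl)methyl in place of 4-fluorophenyl gives, in this assay, a number at least 0.70 log units higher from compound 2 to compound 3 (beyond the scatter), so the entering group's hydrogen-bond acceptor, absent from 4-fluorophenyl, does not go with a lower number in this pair. Compound 2 now stands apart from two compounds with different groups at this place, methyl and (pyridin-2-yl)methyl, and it alone gives an actual number, while the other two end at the same limit: the limit of > 3.7 in this assay, at which 2 of the 3 values shown sit. The step between compound 1 and compound 3 cannot be read, since both values are limits, and the series therefore gives no order for methyl and (pyridin-2-yl)methyl at this place.

The change replaces the ring and adds a chain carbon in a single step, so the compounds shown do not separate the ring nitrogen, the fluorine and the extra carbon; a benzyl or 4-fluorobenzyl group on the same nitrogen would divide that step. From the compounds shown here alone, how far above the limit compound 1 and compound 3 lie remains open, as does the behaviour of an ionisable group at this place, such as a carboxylic acid or an amine on the chain.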